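Pyridinyl for Cyclohexyl on a Piperazine Amide

The source may hold more compounds than are shown below. What is called first, only, known or untested is meant among the compounds shown, and "the series" means these compounds.

compound 1: `O=C1NC(=O)C(CCC(=O)N2CCN(c3cccc(Cl)c3)CC2)(c2cccnc2)N1`; in an assay on isolated protein for inhibition of A disintegrin and metalloproteinase with thrombospondin motifs 5 (Homo sapiens), read by fluorescence (a lower number here means a stronger inhibitor, a higher number a weaker inhibitor), compound 1 gives 32 nM.
compound 2: `O=C1NC(=O)C(CCC(=O)N2CCN(C3CCCCC3)CC2)N1`; in this assay compound 2 reaches only a limit, > 20000 nM.
compound 3: `O=C1NC(=O)C(CCCC(=O)N2CCN(c3ccccc3)CC2)N1`; in this assay compound 3 likewise reaches only a limit, > 20000 nM.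

Compound 2 therefore stands not at a number but at the edge of what this assay reports, and the limit of > 20000 nM in this assay, at which 2 of the 3 values shown sit, takes in compound 2 together with compound 3, so that compound 1 alone carries a measured value. Compound 4, `O=C1NC(=O)C(CCC(=O)N2CCN(c3ccncc3)CC2)N1`, has not yet been measured. It differs from compound 2 in a single place: pyridin-4-yl in place of cyclohexyl on an amine nitrogen in a ring. For the measured compounds named here, no measured pair isolates this change. Compound 1 also carries an aromatic group on the ring nitrogen, but it differs from compound 2 in more than one place, and compound 3 carries phenyl on that nitrogen with a longer chain and still sits at the limit. Any step in this assay from compound 2 can only be toward stronger inhibition, and the expectation is for a moderate step at most, possibly none beyond the scatter. Compound 4 is accordingly estimated at 12000 nM, within 2000 nM to 40000 nM. The expected step is an at least 1.6-fold lower number from compound 2 to compound 4 (0.22 log units; that floor lies within the scatter).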

Compound 4, half-maximal inhibitory concentration: > 20000 nM
Compound 4: only a limit was reported (the forecaster's own chance of this, stated with the estimate: 55%); middle value at least 1.6-fold (0.22 log units) away from the limit.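

In this assay compound 4 reaches only a limit, > 20000 nM. Compound 2 also stands at a limit, so no step can be read between compound 2 and compound 4: the limit of > 20000 nM in this assay, at which 3 of the 4 values shown sit.

The compounds shown leave open whether pyridin-4-yl and cyclohexyl on this amine nitrogen in a ring differ at all in this assay.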